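A carbamate chain gives way to a phenyl ring

The source may hold more compounds than are shown below. What is called first, only, known or untested is meant among the compounds shown, and "the series" means these compounds.

Compound 1 `CC(C)NCCS(=O)(=O)NC(=O)c1ccc(Nc2nc(NC3(c4ccc(Cl)cc4)CC3)nc(OCC(F)(F)F)n2)cc1`: 89%
Compound 2 `CC(C)OC(=O)NCCS(=O)(=O)NC(=O)c1ccc(Nc2nc(NC3(c4ccc(Cl)cc4)CC3)nc(OCC(F)(F)F)n2)cc1`: 100%

In an ADME assay on microsomes from liver (Homo sapiens) for metabolic stability, with a stated time of 10 min (on this read-out higher numbers stand for a more stable compound and lower numbers for a less stable compound), compound 2 gives 100%, the higher of the two numbers, while compound 1 gives 89%. Among the compounds with values here, the only measured step, a number 11 percentage points higher from compound 1 to compound 2 (beyond the scatter), changed just the group on the amine nitrogen. Compound 3 `O=C(NS(=O)(=O)c1ccccc1)c1ccc(Nc2nc(NC3(c4ccc(Cl)cc4)CC3)nc(OCC(F)(F)F)n2)cc1` differs from compound 2 in another place: phenyl in place of 2-((isopropoxycarbonyl)amino)ethyl on a sulfonyl sulfur. Within the data shown here, no measured step touches this part of the molecule, so the data give no direct guide for this assay. With both measured numbers high, compound 3 is expected to show a small drop, a number 15 percentage points lower from compound 2 to compound 3 (beyond the scatter). Compound 3 is therefore estimated at 85%, within a range of 60% to 100%.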

Compound 3, percent of the compound remaining: 100%
Beside the measured number, compound 3's estimate is 15 percentage points below it, and the stated range covers the measured number.
By their numbers in this assay, from the lowest: compound 1; then compounds 2 and 3 (each within the scatter of the next).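

Phenyl on the sulfonyl sulfur does as well as the 2-((isopropoxycarbonyl)amino)ethyl chain in this assay, with no change at the digits printed from compound 2 to compound 3 (within the scatter). Against the amine chain, it gives a number 11 percentage points higher from compound 1 to compound 3 (beyond the scatter), so an aromatic ring with no donors or acceptors can sit at this position and keep the number high. No evidence is available to explain this result.

As far as these compounds go, it remains open how a substituted phenyl, such as a chlorophenyl, or a small group such as methyl would behave at this position. From the compounds shown here alone, a chain ending in a carboxylic acid is equally open.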